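The source may hold more compounds than are shown below. What is called first, only, known or untested is meant among the compounds shown, and "the series" means these compounds.

Measured compounds:
Compound 1 `C=C1C2=C(C(=O)N1OC)[C@H](OC(=O)CSc1nc3ccccc3s1)[C@@](C)(O)[C@H](CCCCC)O2`: 4300 nM
Compound 2 `C=C1C2=C(C(=O)N1OC)[C@H](O)[C@@](C)(O)[C@H](CCCCC)O2`: 20000 nM

In a functional assay on K562 cells (Homo sapiens) for cytotoxicity, read by MTT assay, with a stated time of 72 h (a lower number here means a stronger inhibitor, a higher number a weaker inhibitor), compound 2 gives 20000 nM, the highest of the two numbers recorded so far. Its nearest neighbour is compound 1, which in this assay gives 4300 nM, a lower number that lies beyond the scatter of repeated measurements. The two compounds share the same core, and compound 1 carries an ester on the oxygen where compound 2 has only a hydrogen.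

Compound 3 `C=C1C2=C(C(=O)N1OC)[C@H](OC(=O)CCCCCl)[C@@](C)(O)[C@H](CCCCC)O2` has not yet been measured. It differs from compound 2 in one place: (4-chlorobutyl)carbonyl in place of hydrogen on an oxygen on a saturated carbon. Among the measured compounds shown here, no measured pair shows this exact step, so its size can only be guessed. Compound 3 is expected to sit somewhere between the two measured numbers, because in this assay compound 1 gives 4300 nM after a different acyl group enters the same oxygen. The estimated step of a 2.5-fold lower number from compound 2 to compound 3 (0.40 log units; beyond the scatter) is expected to fall toward a lower number, probably beyond the scatter. For compound 3 the estimate is 8000 nM, within a range from 3000 nM to 20000 nM.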

Compound 3, half-maximal inhibitory concentration: 8500 nM
Compound 3: the middle estimate sits 1.1-fold (0.03 log units) below what was measured, within the range that was stated.
By their numbers in this assay, from the lowest: compounds 1 and 3 (each within the scatter of the next); then compound 2.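

Across the two esters shown, acylation of this oxygen on a saturated carbon goes with a lower number than the free hydroxy in this assay. The flexible, ring-free (4-chlorobutyl)carbonyl group gives a modest change beyond the scatter (a 2.4-fold lower number from compound 2 to compound 3 (0.37 log units; beyond the scatter)), so the lower number in this pair does not depend on a ring in the acyl group. Exchanging (1,3-benzothiazol-2-yl)sulfanyl for 3-chloropropyl on the saturated chain carbon bound to the carbonyl carbon gives a step within the scatter (a 2.0-fold higher number from compound 1 to compound 3 (0.30 log units; within the scatter)), so these two very different acyl groups cannot be told apart here, and no measurement is available to explain this result.

The compounds shown leave open whether the chlorine in compound 3 matters at all, since they do not compare it with an unsubstituted pentanoyl group or with a bromine at the same chain end. They also do not tell how the number would respond to a longer chain, or to an amine or a carboxylic acid at the end of that chain.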